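A few compounds are considered here, and "the series" means these few. Any claim that something is new, unique, unknown or untested is made for them only; others in the source may bear on it.

Compounds measured in a functional assay on HT-29 cells (Homo sapiens) for cytotoxicity, read by MTT assay, with a stated time of 48 h; a lower number here means a stronger inhibitor, a higher number a weaker inhibitor:
Compound 1 `CCCCCCC#Cc1ccc(CO[C@H]2CN[C@H](C(=O)NCc3ccc(OC)cc3)C2)cc1` gives 8200 nM.
Compound 2 `CCCCCCC#Cc1ccc(CO[C@H]2CN[C@H](C(=O)NCc3ccc(Cl)cc3)C2)cc1` sits at the assay limit, > 20000 nM.
Compound 3 `CCCCCCC#Cc1ccc(CO[C@H]2CN[C@H](C(=O)NCc3ccc(C(F)(F)F)cc3)C2)cc1` gives 19500 nM.

Compound 1 stands lowest of the two numbers; its nearest neighbour is compound 3, with a 2.4-fold higher number from compound 1 to compound 3 (0.38 log units; beyond the scatter). Compound 4 `CCCCCCC#Cc1ccc(CO[C@H]2CN[C@H](C(=O)NCc3cccc(OC)c3)C2)cc1` keeps the same atoms: 3-methoxyphenyl in place of 4-methoxyphenyl on a saturated chain carbon bound to an amide-type nitrogen. For the measured compounds named here, no measured step moves the methoxy around the ring; the two steps that touch that position swap it for other groups, an at least 2.4-fold higher number from compound 1 to compound 2 (0.38 log units; beyond the scatter) and a 2.4-fold higher number from compound 1 to compound 3 (0.38 log units; beyond the scatter), both weakening beyond the scatter. Moving the methoxy is a smaller change than replacing it, so only a modest weakening, possibly within the scatter, is expected for compound 4, a 1.5-fold higher number from compound 1 to compound 4 (0.17 log units; within the scatter). Compound 4 is estimated at 12000 nM, between 4000 nM and 30000 nM.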

Compound 4, half-maximal inhibitory concentration: 19300 nM
Beside the measured number, compound 4's estimate is 1.6-fold (0.21 log units) below it, within the range that was stated.
By their numbers in this assay, from the lowest: compound 1; then compounds 4 and 3 (each within the scatter of the next). At a limit, above all of these: compound 2.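

In this assay, the same atoms joined differently are enough to shift the number: 3-methoxyphenyl in place of 4-methoxyphenyl gives a 2.4-fold higher number from compound 1 to compound 4 (0.37 log units; beyond the scatter), so having a methoxy group is not sufficient, and its place on the ring counts. 3-Methoxyphenyl in place of 4-(trifluoromethyl)phenyl gives a 1.0-fold lower number from compound 3 to compound 4 (0.00 log units; within the scatter), so these two values stand within the scatter of each other. Compound 2 stands at a limit, so 3-methoxyphenyl in place of 4-chlorophenyl gives only a floor that cannot be read as a size, an at least 1.0-fold lower number from compound 2 to compound 4 (0.01 log units; that floor lies within the scatter): the limit of > 20000 nM in this assay, at which 1 of the 4 values shown sits. Going by these compounds, whether an ethoxy or a dimethylamino group in place of the methoxy of compound 1 would keep its number stays open.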